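Dropping the phenoxy group from compound 2

This account rests on a few compounds, and the source may have more. Where it says the series, first, only, none or still open, it means among the compounds named here.

Measured so far:
compound 1, `Cc1cccc(C(=O)NC(CCN(C)C)c2ccc(Cl)cc2)c1C`, 159%
compound 2, `CN(C)CCC(NC(=O)c1ccc(Oc2ccccc2)cc1)c1ccc(Cl)cc1`, 89%

In an assay on NIH3T3 cells with Urotensin-2 receptor (Homo sapiens) as the target (on this read-out higher numbers stand for larger maximal responses and lower numbers for smaller maximal responses), compound 1 gives 159%. In this assay compound 2 gives 89%, the lowest of the two numbers, and compound 1 stands a long way higher, beyond the scatter. The two share a core, and the change from compound 2 to compound 3, `CN(C)CCC(NC(=O)c1ccccc1)c1ccc(Cl)cc1`, is hydrogen in place of phenoxy on an aromatic carbon. For the measured compounds named here, no pair of measured compounds differs in a single place, so the size of such a step is not known from the data. Compound 3 carries neither the phenoxy of compound 2 nor the two methyl groups of compound 1, and its maximal response is expected to fall between those two, a rise beyond the scatter from compound 2 of about a number 26 percentage points higher from compound 2 to compound 3 (beyond the scatter). Compound 3 is thus estimated at 115%, within 75% to 160%.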

Compound 3, largest response reached (reported as efficacy), in percent of the reference or control that the assay uses: 158%
For compound 3 the middle estimate is 43 percentage points below the measured one; low and high end bracket the measured number.
By their numbers in this assay, from the lowest: compound 2; then compounds 3 and 1 (each within the scatter of the next).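

Hydrogen in place of phenoxy, on an aromatic carbon para to a large group, gives a number 69 percentage points higher from compound 2 to compound 3 (beyond the scatter) in this assay and so provides the first single-place measure of a change at this position, showing that it can shift the maximal response by a large amount. The second step, phenyl in place of 2,3-dimethylphenyl on a carbonyl carbon, comes to a number 1 percentage points lower from compound 1 to compound 3 (within the scatter) and so shows that the two methyl groups of compound 1 make no difference beyond the scatter on this read-out. Nothing at hand gives a reason for either result.

The compounds shown leave open whether the large step belongs to the whole phenoxy group or only to part of it, as a methoxy group or a directly attached phenyl on the same aromatic carbon would show. Also open, from the compounds shown here alone, is where a fluorine atom or an amine on that carbon would stand relative to compound 2 and compound 3.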